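Trifluoromethyl for chloro on the benzyl arm

The source may hold more compounds than are shown below. What is called first, only, known or untested is meant among the compounds shown, and "the series" means these compounds.

Measured compounds:
compound 1 `O=C(NCc1cn(Cc2ccc(C(F)(F)F)cc2)nn1)c1cn(-c2ccccc2)nc1-c1ccc(F)cc1`, 250 nM
compound 2 `O=C(NCc1cn(Cc2ccc(F)cc2)nn1)c1cn(-c2ccccc2)nc1-c1ccc(Cl)cc1`, 2800 nM
compound 3 `O=C(NCc1cn(Cc2ccc(Cl)cc2)nn1)c1cn(-c2ccccc2)nc1-c1ccc(Cl)cc1`, 470 nM

In a functional assay on HeLa cells (Homo sapiens) for antiproliferative activity, read by sulforhodamine B assay, with a stated time of 48 h (a higher number here means a weaker inhibitor of growth, a lower number a stronger inhibitor of growth), compound 3 stands second highest of the three numbers, within the scatter of compound 1 and well apart from compound 2. Going by the values given here, the one single-site step known here, a 6.0-fold lower number from compound 2 to compound 3 (0.78 log units; beyond the scatter), came from a chloro in place of a fluoro on the benzyl ring. Compound 4 `O=C(NCc1cn(Cc2ccc(C(F)(F)F)cc2)nn1)c1cn(-c2ccccc2)nc1-c1ccc(Cl)cc1` differs from compound 3 in that same place: trifluoromethyl in place of chloro on an aromatic carbon. Compound 1 already carries this trifluoromethyl benzyl and gives a number close to compound 3, though it differs from compound 3 in a second place as well. Compound 4 is therefore expected to move only a little, a 1.9-fold lower number from compound 3 to compound 4 (0.27 log units; within the scatter), with an estimate of 250 nM and a range from 100 nM to 700 nM in this assay.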

Compound 4, concentration for 50% growth inhibition: 1900 nM
The estimate for compound 4 lay 7.6-fold (0.88 log units) below the measured number; the whole stated range lies below it.
By their numbers in this assay, from the lowest: compounds 1 and 3 (each within the scatter of the next); then compounds 4 and 2 (each within the scatter of the next).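

In this assay, with the 4-chlorophenyl on the shared core, trifluoromethyl in place of chloro on the benzyl ring gives a 4.0-fold higher number from compound 3 to compound 4 (0.61 log units; beyond the scatter), while trifluoromethyl in place of fluoro gives a 1.5-fold lower number from compound 2 to compound 4 (0.17 log units; within the scatter), so chloro alone stands apart among these three groups at this position. Chloro in place of fluoro on the other aromatic ring, with the 4-(trifluoromethyl)benzyl held, gives a 7.6-fold higher number from compound 1 to compound 4 (0.88 log units; beyond the scatter), so this change does not read the same in both places: the same change on two cores in this assay, a 6.0-fold lower number (0.78 log units; beyond the scatter) from compound 2 to compound 3 and a 7.6-fold higher number (0.88 log units; beyond the scatter) from compound 1 to compound 4, 45-fold (1.66 log units) apart, beyond the scatter of two such steps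

As far as these compounds go, it remains open whether bromo or methoxy on the benzyl ring would match chloro, and whether chloro there would keep its standing on the core of compound 1.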